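The source may hold more compounds than are shown below. What is called first, only, known or untested is meant among the compounds shown, and "the series" means these compounds.

Measured in a functional assay on HeLa cells (Homo sapiens) for antiproliferative activity, read by MTT assay, with a stated time of 48 h; a higher number here means a weaker inhibitor of growth, a lower number a stronger inhibitor of growth:
- compound 1 `COC(=O)N1N=C(c2ccccc2)CC1c1cc(OC)c(OC)c(OC)c1`: 2180 nM
- compound 2 `COC(=O)N1N=C(c2ccc(OC)cc2)CC1c1cc(OC)c(OC)c(OC)c1`: 2590 nM
- compound 3 `COc1ccc(C2=NN(C(=O)OCc3ccccc3)C(c3cc(OC)c(OC)c(OC)c3)C2)cc1`: > 10000 nM, a limit of the assay

Among the numeric values, compound 2 at 2590 nM stands level with compound 1 at 2180 nM, the two lying within the scatter of each other. The value of compound 3 is a limit and not a number.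

Next in the series is compound 4 `COC(=O)N1N=C(c2cccc(C)c2)CC1c1cc(OC)c(OC)c(OC)c1`, which differs from compound 2 by 3-methylphenyl in place of 4-methoxyphenyl on a carbon with a double bond to nitrogen.

Among the compounds with values here, only one measured step touches this group: methoxy in place of hydrogen on an aromatic carbon gave a 1.2-fold higher number from compound 1 to compound 2 (0.07 log units; within the scatter). The other measured step, an at least 3.8-fold higher number from compound 2 to compound 3 (0.58 log units; beyond the scatter), lies on the chain bound to the carbonyl group, elsewhere in the molecule, and says little about this change. Within the data shown here, no measured compound carries 3-methylphenyl, so the expectation is loose and leans on the one small step. No step beyond the scatter is expected in this assay, and no direction is favoured. The expected change is a 1.0-fold lower number from compound 2 to compound 4 (0.02 log units; within the scatter). For compound 4 the estimated value is 2500 nM, with an expected range of 1000 nM to 6000 nM.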

Compound 4, concentration for 50% growth inhibition: 50 nM
Beside the measured number, compound 4's estimate is 50-fold (1.70 log units) above it, outside the stated range (below it).
By their numbers in this assay, from the lowest: compound 4; then compounds 1 and 2 (each within the scatter of the next). At a limit, above all of these: compound 3.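

In this assay, the aryl group on the carbon with a double bond to nitrogen proves to be a place of large effect: the change to 3-methylphenyl gives a 52-fold lower number from compound 2 to compound 4 (1.71 log units; beyond the scatter). The earlier methoxy step, a 1.2-fold higher number from compound 1 to compound 2 (0.07 log units; within the scatter), described a single substituent and gave no sign of how much this position can respond, so the small size of that step cannot be taken as a property of the position as a whole. The 3-methylphenyl differs from the unsubstituted phenyl by one methyl, and that single addition gives a 44-fold lower number from compound 1 to compound 4 (1.64 log units; beyond the scatter), so a gain of this size does not depend on removing a methoxy group, only on adding this methyl to the phenyl.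

On these data alone, whether the gain belongs to the methyl itself or to where it sits on the ring stays open, and so does what an ethyl, a chloro or an amino group would do on that ring. Nothing among the data shown gives a cause for the gain.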